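Compound 3 to compound 4: cyano in place of fluoro

The compounds below may be only part of what the source reports. "The series", "measured", "known", "first", "only" and "open" are said of these compounds alone.

Three amides of the shared core have been read in an ADME assay on microsomes from liver (Mus musculus) for metabolic stability, with a stated time of 10 min; a lower number here means that less of the compound is left, a higher number that more of the compound is left. Compound 1 `CC(=O)N1CC[C@@H](C(=O)N2CC[C@](c3ccc(C(OCc4c(F)cccc4F)(C(F)(F)F)C(F)(F)F)cc3)(S(=O)(=O)c3ccc(F)cc3)C2)C1`, with 1-acetylpyrrolidin-3-yl on the carbonyl carbon, gives 55%. Compound 2 `CC(=O)N1CCC(C)(C(=O)N2CC[C@](c3ccc(C(OCc4c(F)cccc4F)(C(F)(F)F)C(F)(F)F)cc3)(S(=O)(=O)c3ccc(F)cc3)C2)CC1`, with 1-acetyl-4-methylpiperidin-4-yl there, gives 4%. Compound 3 `CC(=O)N1CCN(C(=O)N2CC[C@](c3ccc(C(OCc4c(F)cccc4F)(C(F)(F)F)C(F)(F)F)cc3)(S(=O)(=O)c3ccc(F)cc3)C2)CC1`, with 4-acetylpiperazin-1-yl, gives 59%, which is level with compound 1 within the scatter and far from compound 2.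

Compound 4 `CC(=O)N1CCN(C(=O)N2CC[C@](c3ccc(C(OCc4c(F)cccc4C#N)(C(F)(F)F)C(F)(F)F)cc3)(S(=O)(=O)c3ccc(F)cc3)C2)CC1` keeps the 4-acetylpiperazin-1-yl group and turns 2,6-difluorobenzyl into 2-cyano-6-fluorobenzyl, with cyano in place of fluoro on an aromatic carbon.

All measured steps lie on the carbonyl carbon, and none touches the (2,6-difluorobenzyl)oxy group. The step of a number 4 percentage points higher from compound 1 to compound 3 (within the scatter) stays within the scatter, while a number 51 percentage points lower from compound 1 to compound 2 (beyond the scatter) and a number 55 percentage points higher from compound 2 to compound 3 (beyond the scatter) are large. These steps give no direction for the new change, but they show that one change can move the read-out in this assay strongly, and the range is kept wide on that account. No step beyond the scatter is expected, and the estimated step is a number 4 percentage points lower from compound 3 to compound 4 (within the scatter). For compound 4 the estimated value is 55%, with an expected range from 35% to 75%.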

Compound 4, percent of the compound remaining: 1%
The estimate for compound 4 lay 54 percentage points above the measured number; the measured number lies below the stated range.
By their numbers in this assay, from the lowest: compounds 4 and 2 (each within the scatter of the next); then compounds 1 and 3 (each within the scatter of the next).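

In this assay, among the compounds shown here, the (2,6-difluorobenzyl)oxy group, which no earlier step touched, proves to be a second place where one change moves the read-out strongly: cyano in place of fluoro on an aromatic carbon gives a number 58 percentage points lower from compound 3 to compound 4 (beyond the scatter). For the compounds shown here, until now, the large steps all lay on the carbonyl carbon, and the 4-acetylpiperazin-1-yl group had been seen only with the 2,6-difluorobenzyl group; with 2-cyano-6-fluorobenzyl, the same amide no longer keeps a high number. No measurement at hand bears on why the number falls or on which part of the molecule is involved.

On these data alone, it remains open whether this step follows from the entering cyano or from the leaving fluoro, and a hydrogen, chloro or methyl group at the same aromatic carbon would help to separate the two. As far as these compounds go, it is also open whether the same exchange of fluoro for cyano gives a step of similar size with 1-acetylpyrrolidin-3-yl on the carbonyl carbon, which would show whether the effect depends on the amide.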